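Benzyl in place of methyl on the quaternary nitrogen

This account rests on a few compounds, and the source may have more. Where it says the series, first, only, none or still open, it means among the compounds named here.

Two aryloxy ketones bearing a quaternary nitrogen on the aromatic ring are measured in a functional assay with Cavia porcellus as the target; on this read-out higher numbers stand for weaker inhibition and lower numbers for stronger inhibition. Compound 1 `COc1ccc(C(=O)COc2cccc([N+](C)(C)C)c2)cc1OC` gives 7080 nM. Compound 2 `COc1ccc(C(=O)COc2cccc([N+](C)(C)Cc3ccccc3)c2)cc1OC`, which carries phenyl in place of hydrogen on a saturated chain carbon bound to a nitrogen on an aromatic ring, gives 1690 nM. For the measured compounds named here, the step of a 4.2-fold lower number from compound 1 to compound 2 (0.62 log units; beyond the scatter) is the only one measured for this change.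

Compound 3 `COc1ccc(C(=O)COc2ccc([N+](C)(C)C)cc2)cc1OC` has the same atoms as compound 1 joined differently; the difference between the two cores is not broken down here. In this assay compound 3 gives 9800 nM, a number that lies within the usual scatter of the value of compound 1, so no order between these two can be read from the data.

Compound 4 `COc1ccc(C(=O)COc2ccc([N+](C)(C)Cc3ccccc3)cc2)cc1OC` is not yet measured. It stands to compound 3 as compound 2 stands to compound 1: the change is phenyl in place of hydrogen on a saturated chain carbon bound to a nitrogen on an aromatic ring, and the place is described in the same words for both pairs, so the change is the same one. With only one measured occurrence, the expectation rests on that single step, a 4.2-fold lower number from compound 1 to compound 2 (0.62 log units; beyond the scatter), transferred to the core of compound 3. Compound 4 is therefore expected to show a step of about a 4.1-fold lower number from compound 3 to compound 4 (0.61 log units; beyond the scatter) in this assay, and its estimated value is 2400 nM, with a likely range from 1000 nM to 6000 nM. From the compounds shown here alone, whether the other core carries the change equally well is unknown, which widens the range.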

Compound 4, half-maximal inhibitory concentration: 19400 nM
For compound 4 the middle estimate is 8.1-fold (0.91 log units) below the measured one; the measured number lies above the stated range.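

In this assay, methyl to benzyl on the core of compound 3 gives a 2.0-fold higher number from compound 3 to compound 4 (0.30 log units; within the scatter), so the data set no order between these two compounds. The change therefore does not carry across the two cores, and the step read on the core of compound 1 is no guide to its effect on the core of compound 3: the same change on two cores in this assay, a 4.2-fold lower number (0.62 log units; beyond the scatter) from compound 1 to compound 2 and a 2.0-fold higher number (0.30 log units; within the scatter) from compound 3 to compound 4, 8.3-fold (0.92 log units) apart, beyond the scatter of two such steps

This conclusion rests on a single pair on each core, and it does not show what separates the cores or how general either step is within the series, since compound 2 and compound 4 are the only benzyl compounds shown.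

The compounds shown leave open whether the divergence is specific to benzyl or also appears with other groups on the quaternary nitrogen, such as ethyl, a longer chain such as n-butyl, or 2-phenylethyl. They also leave open whether a tertiary amine in place of the quaternary nitrogen, or a substituted benzyl such as 4-methoxybenzyl, would follow the trend seen on the core of compound 1, the one seen on the core of compound 3, or neither.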